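The compounds below may be only part of what the source reports. "The series", "measured", "known", "first", "only" and "open" are said of these compounds alone.

In an ADME assay on a cell-free system (plasma, Mus musculus) for metabolic stability, read by LC-MS, tested at 2 uM (a higher number here means that the compound lasts longer, a lower number that the compound disappears faster), compound 3 (`CCCCCNC(=O)n1c(=O)oc2cc(C3CCN(C)CC3)ccc21`) gives 1.25 h and compound 2 (`CC(C)CNC(=O)n1c(=O)oc2cc(C3CCN(C)CC3)ccc21`) gives 1.33 h as its value, the two lying within the scatter of each other (a 1.1-fold lower number from compound 2 to compound 3 (0.03 log units; within the scatter)). Compound 1 (`CN1CCC(c2ccc3c(c2)oc(=O)n3C(=O)NCCCCc2ccc(F)cc2)CC1`) gives 0.333 h as the lowest value of the three. Compound 4 (`CN1CCC(c2ccc3c(c2)oc(=O)n3C(=O)NCCOCc2ccccc2)CC1`) carries benzyloxy in place of propyl on a saturated chain carbon, two bonds along the chain from an amide-type nitrogen. Within the data shown here, compound 1 is the only measured compound with an aromatic ring on its chain, and compound 4 also has one. The closest guides, read in reverse, are therefore two modest steps (a 3.8-fold higher number from compound 1 to compound 3 (0.57 log units; beyond the scatter) and a 4.0-fold higher number from compound 1 to compound 2 (0.60 log units; beyond the scatter)). On these data alone, no measured chain holds an ether oxygen, so that part of the change is untested. A modest drop of similar size is expected in this assay (a 2.8-fold lower number from compound 3 to compound 4 (0.44 log units; beyond the scatter)). For compound 4 the expected value is 0.45 h (estimated range 0.2 h to 1 h).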

Compound 4, half-life in the Mus musculus assay: 0.667 h
Compound 4: the middle estimate sits 1.5-fold (0.17 log units) below what was measured, and the stated range covers the measured number.
By their numbers in the Mus musculus assay, from the lowest: compounds 1, 4, 3 and 2 (each within the scatter of the next, the first and the last beyond it).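

In the Mus musculus assay, the new chain with benzyloxy at this position shows no step beyond the scatter against any earlier compound: a 1.9-fold lower number from compound 3 to compound 4 (0.27 log units; within the scatter), a 2.0-fold lower number from compound 2 to compound 4 (0.30 log units; within the scatter) and a 2.0-fold higher number from compound 1 to compound 4 (0.30 log units; within the scatter). A chain with both an aromatic ring and an ether oxygen therefore cannot be separated here from the alkyl chains of compound 2 and compound 3 or from the 4-fluorophenyl chain of compound 1, even though those earlier chains stand beyond the scatter of each other. In a physicochemical assay for solubility, read by HPLC, in phosphate buffer, measured as kinetic solubility, with a stated time of 1 h, at pH 7.4, tested at 250 uM (a lower number here means a less soluble compound, a higher number a more soluble compound), compound 3 gives 240000 nM and compound 4 gives 73000 nM, and the change from propyl to benzyloxy does give a step beyond the scatter: the measured solubility of compound 3, 240000 nM, and of compound 4, 73000 nM, a 3.3-fold lower number (0.52 log units; beyond the scatter).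

On these data alone, what the ether oxygen and the phenyl ring each contribute stays open; a methoxy group at this position would separate them. As far as these compounds go, how a terminal amine or carboxylic acid on the chain would read also stays open.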